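Aryl variation on the triazole nitrogen of a bicyclic lactam

The compounds below may be only part of what the source reports. "The series", "measured", "known", "first", "only" and "open" are said of these compounds alone.

Measured so far:
compound 1, `CC1(C)[C@H]2CC[C@]1(C)N(Cc1cn(-c3ccccc3Br)nn1)C(=O)C2`: 500 nM
compound 2, `Cc1ccc(-n2cc(CN3C(=O)C[C@@H]4CC[C@@]3(C)C4(C)C)nn2)cc1`: 390 nM

Both measured compounds share the same core and differ only in the aryl group on the aromatic nitrogen. In a functional assay on SGC-7901 cells (Homo sapiens) for inhibition, read by MTT assay, with a stated time of 24 h (on this read-out higher numbers stand for weaker inhibition and lower numbers for stronger inhibition), compound 1 gives 500 nM; this is the highest of the two numbers, and the nearest neighbour is compound 2 with 390 nM. Among the compounds with values here, the single measured step, a 1.3-fold lower number from compound 1 to compound 2 (0.11 log units; within the scatter), lies within the scatter, so the two compounds cannot be ordered on these data.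

Compound 3, `COc1cccc(-n2cc(CN3C(=O)C[C@@H]4CC[C@@]3(C)C4(C)C)nn2)c1`, has not been measured. It differs from compound 1 as follows: 3-methoxyphenyl in place of 2-bromophenyl on an aromatic nitrogen. Within the data shown here, the only step that bears on this change is the one from compound 1 to compound 2, also an exchange of the 2-bromophenyl on the aromatic nitrogen, and it was within the scatter. Among the measured compounds shown here, with that as the sole precedent, no step beyond the scatter is expected for compound 3 in this assay, in either direction; the expected step is a 1.1-fold lower number from compound 1 to compound 3 (0.05 log units; within the scatter). The estimate for compound 3 is therefore 450 nM, with a range from 200 nM to 1000 nM.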

Compound 3, half-maximal inhibitory concentration: 590 nM
For compound 3 the middle estimate is 1.3-fold (0.12 log units) below the measured one; the measured number falls inside the stated range.
By their numbers in this assay, from the lowest: compounds 2, 1 and 3 (each within the scatter of the next).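

In this assay, 3-methoxyphenyl in place of 2-bromophenyl on the aromatic nitrogen gives a 1.2-fold higher number from compound 1 to compound 3 (0.07 log units; within the scatter) and 3-methoxyphenyl in place of 4-methylphenyl gives a 1.5-fold higher number from compound 2 to compound 3 (0.18 log units; within the scatter). Within the data shown here, this position now carries three substituted phenyl groups, and no pair among compound 1, compound 2 and compound 3 is separated beyond the scatter, so the earlier null result is no longer confined to a single exchange. The 3-methoxyphenyl group also brings a hydrogen-bond acceptor and an oxygen that the other two groups lack, yet neither step leaves the scatter, and no measurement at hand accounts for this flat response.

Each of the three rings differs from the others in both the substituent and its place on the ring, so these two variables cannot be separated, and the same substituent has not been compared at different places. Also open, from the compounds shown here alone, is whether the flat response holds for a phenyl ring bearing an amine or a carboxylic acid, or for a pyridine ring or benzyl group on the same nitrogen.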